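The compounds below may be only part of what the source reports. "The series", "measured", "known", "first", "only" and "open" are said of these compounds alone.

Measured compounds in a functional assay on SiHa cells (Homo sapiens) for cytotoxicity, read by MTT assay, with a stated time of 48 h; a higher number here means a weaker inhibitor, a lower number a stronger inhibitor:
- compound 1 `CCCCCCCCCCCCCCCCCCNC(=O)[C@@H](NC(=O)c1nccc2ccccc12)[C@@H](C)O` gives 51200 nM
- compound 2 `CCCCCCCCCCCCCCCCCCNC(=O)[C@@H](NC(=O)/C=C/c1ccccc1)[C@@H](C)O` gives 35900 nM

Within the data shown here, compound 2 has the lowest of the two numbers, but its only neighbour is compound 1, and the step of a 1.4-fold lower number from compound 1 to compound 2 (0.15 log units; within the scatter) lies within the scatter, so the two compounds cannot be told apart on potency. Compound 3 `CCCCCCCCCCCCCCCCCCNC(=O)[C@@H](NS(=O)(=O)c1ccc(C)cc1)[C@@H](C)O` is not yet measured. It differs from compound 2 in one place: (4-methylphenyl)sulfonyl in place of (2-phenylethenyl)carbonyl on an amine nitrogen. Among the measured compounds shown here, the single measured step, from compound 1 to compound 2, swapped one group on the same carbonyl carbon and barely moved the number, so the shared core with its long chain seems to set the weak activity. For the measured compounds named here, no measured step tests replacing the carbonyl itself by a sulfonyl group. For compound 3 the step of a 1.3-fold higher number from compound 2 to compound 3 (0.10 log units; within the scatter) is therefore expected to stay within the scatter. Compound 3 is estimated at 45000 nM, with a range from 15000 nM to 130000 nM in this assay.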

Compound 3, half-maximal inhibitory concentration: 29800 nM
The estimate for compound 3 lay 1.5-fold (0.18 log units) above the measured number; the range from low to high includes it.
By their numbers in this assay, from the lowest: compounds 3, 2 and 1 (each within the scatter of the next).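

In this assay, a sulfonyl group can take the place of the carbonyl on the amine nitrogen without a readable effect: the swap from (2-phenylethenyl)carbonyl gives a 1.2-fold lower number from compound 2 to compound 3 (0.08 log units; within the scatter) and the swap from (isoquinolin-1-yl)carbonyl gives a 1.7-fold lower number from compound 1 to compound 3 (0.24 log units; within the scatter), and both lie within the scatter. Among these compounds, until now only the group on the carbonyl carbon had been exchanged, so this is the first sign that the linking group at this position can also change while the numbers stay within the scatter. Nothing measured here offers a reason for this result.

All three compounds share the same long chain and the same hydroxyl-bearing side chain. From the compounds shown here alone, whether a free amine at this nitrogen, or a shorter chain in place of the long one, would move the number beyond the scatter remains open.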